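A few compounds are considered here, and "the series" means these few. Any claim that something is new, unique, unknown or untested is made for them only; others in the source may bear on it.

Measured compounds in a functional assay on MCF7 cells (Homo sapiens) for inhibition, read by sulforhodamine B assay, with a stated time of 48 h; on this read-out higher numbers stand for weaker inhibition and lower numbers for stronger inhibition:

- compound 1, `CCNC(=O)Nc1ccc(/C=C/c2cc(C)cc(C)c2)cc1`: 20000 nM
- compound 2, `O=C1NCCN1c1ccc(/C=C/c2cccc(Cl)c2)cc1`: 20000 nM
- compound 3, `Cc1cc(C)cc(/C=C\c2ccc(N3CCNC3=O)cc2)c1`: 23 nM

Compound 2 stands level with compound 1 at the digits reported, the two together at the high end of the three numbers, with no change between them within the scatter. Compound 3 sits far below both: against compound 2 it reads a much lower number, a gap well beyond the scatter. Within the data shown here, compound 3 is also the only one of the three in which the double bond is drawn Z; it differs from compound 2 in more than one place, so no single step to it can be read off.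

Compound 4, `O=C1NCCN1c1ccc(/C=C\c2cccc(Cl)c2)cc1`, is still to be measured. It differs from compound 2 as follows: the two compounds have the same atoms and bonds and differ only in configuration as drawn: 1 of 1 stereo elements differ; a double bond is drawn E in compound 2 and Z in compound 4. Among the measured compounds shown here, no step between measured compounds isolates this change. Given that compound 3, the one Z-drawn compound, gives 23 nM in this assay, a large step toward a lower number is expected for compound 4, though the absence of a clean comparison leaves the size uncertain. Compound 4 is estimated at 100 nM, with a range of 15 nM to 2000 nM, which would mean an expected step of a 200-fold lower number from compound 2 to compound 4 (2.30 log units; beyond the scatter).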

Compound 4, half-maximal inhibitory concentration: 38 nM
The estimate for compound 4 lay 2.6-fold (0.42 log units) above the measured number, within the range that was stated.
By their numbers in this assay, from the lowest: compounds 3 and 4 (each within the scatter of the next); then compounds 1 and 2 (each within the scatter of the next).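

Working notes: in this assay, the double bond is now isolated as a single change, and turning it from E to Z gives a 530-fold lower number from compound 2 to compound 4 (2.72 log units; beyond the scatter). The full size of this step can be assigned to the double bond configuration, because nothing else in the pair varies: the fact that compounds 2 and 4 differ only in the configuration as drawn

Before this pair, the Z drawing occurred only in compound 3, which differs from the E compounds in more than one place, so its low number could not be assigned to configuration; the effect is still shown for only this one pair.

Steps among the other compounds cannot be read, so whether the change has a similar size with the ethyl urea of compound 1 remains open. Also open, going by these compounds, is how the Z compounds respond when a methoxy group or a fluorine replaces the chlorine.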